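This account rests on a few compounds, and the source may have more. Where it says the series, first, only, none or still open, it means among the compounds named here.

Compound 1, `CN1C(=O)/C(=C/N2N=C(c3ccccc3)CC2c2ccccc2O)SC1=S`: 341 nM
Compound 2, `CCN1C(=O)/C(=C/N2N=C(c3ccccc3)CC2c2ccccc2O)SC1=S`: > 10000 nM
Compound 3, `O=C1/C(=C/N2N=C(c3ccccc3)CC2c2ccccc2O)SC(=S)N1c1cccnc1`: > 10000 nM

Three compounds share one core and differ only in the group carried by the amide-type nitrogen of the five-membered ring. Among the compounds with values here, in a functional assay on SK-OV-3 cells (Homo sapiens) for antiproliferative activity, read by MTT assay, with a stated time of 72 h (a higher number here means a weaker inhibitor, a lower number a stronger inhibitor), compound 1 gives 341 nM and is the only compound with a measured number. For compound 2 the assay reports only a limit, > 10000 nM. For compound 3 the assay likewise reports only a limit, > 10000 nM. Compound 3 therefore stands at the limit of > 10000 nM in this assay, at which 2 of the 3 values shown sit, together with compound 2, and no number separates the two.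

The measured steps leading there are an at least 29-fold higher number from compound 1 to compound 2 (1.46 log units; beyond the scatter) and an at least 29-fold higher number from compound 1 to compound 3 (1.46 log units; beyond the scatter), while a step that the two limits leave unreadable from compound 2 to compound 3.

Compound 4, `O=C1/C(=C/N2N=C(c3ccccc3)CC2c2ccccc2O)SC(=S)N1c1cccc(C(F)(F)F)c1`, differs from compound 3 in one place: 3-(trifluoromethyl)phenyl in place of pyridin-3-yl on an amide-type nitrogen in a ring. Within the data shown here, no measured step swaps one aromatic group for another on this nitrogen; the only measured step that brought an aromatic group there, an at least 29-fold higher number from compound 1 to compound 3 (1.46 log units; beyond the scatter), ended at the limit. Compound 4 is therefore expected to give about 15000 nM in this assay, in a range from 3000 nM to 60000 nM, most likely again as a limit. The expected step that the limit leaves unreadable from compound 3 to compound 4 is accordingly small and not readable beyond the scatter.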

Compound 4, half-maximal inhibitory concentration: > 10000 nM
Compound 4 gave a limit, no number; the forecaster's own chance of this, stated with the estimate: 65%; the middle value lies beyond the limit too.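

Putting 3-(trifluoromethyl)phenyl in place of methyl on the amide-type nitrogen brings an at least 29-fold higher number from compound 1 to compound 4 (1.46 log units; beyond the scatter), so a third group at this position fails to keep the activity of compound 1 in this assay. Compound 2, compound 3 and compound 4 all give limits rather than numbers, and the steps among them cannot be read, so these three groups cannot be ranked. Of the groups shown on this nitrogen, only methyl gives a measured number, while an open chain, a ring containing nitrogen and a ring of carbon only all end at the same place: the limit of > 10000 nM in this assay, at which 3 of the 4 values shown sit.

Going by these compounds, it remains open whether methyl itself is needed here, or whether a plain hydrogen or a cyclopropyl group on this nitrogen would also give a measurable number. On these data alone, how far compound 2, compound 3 and compound 4 lie beyond their shared limit also remains unknown.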